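Swapping methoxy for cyclopropylamino at an assay limit

A few compounds are considered here, and "the series" means these few. Any claim that something is new, unique, unknown or untested is made for them only; others in the source may bear on it.

In an ADME assay on Huh-7 cells (Homo sapiens) for cytotoxicity, read by MTT assay, with a stated time of 4 days (on this read-out lower numbers stand for higher toxicity in this test and higher numbers for lower toxicity in this test), compound 1 `Nc1ncnc2c1ncn2[C@H]1CO[C@@H](CO)O1` gives > 100000 nM, which is a limit and not a number. Compound 2 `COc1ncnc2c1ncn2[C@H]1CO[C@@H](CO)O1` gives > 100000 nM, which is also a limit. Compound 2 therefore stands at the limit of > 100000 nM in this assay, at which 2 of the 2 values shown sit, with no number to mark its exact place.

Compound 3 `OC[C@@H]1OC[C@H](n2cnc3c(NC4CC4)ncnc32)O1` carries cyclopropylamino in place of methoxy on an aromatic carbon, the change counted as cyclopropylamino in place of methoxy on an aromatic carbon.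

For the measured compounds named here, only one measured step bears on this change: a step that the two limits leave unreadable from compound 1 to compound 2, with methoxy in place of amino on an aromatic carbon. It offers no size to carry over, so no step beyond the scatter is expected in this assay, and no direction can be assigned. The expected outcome is a number no higher from compound 2 to compound 3 (the limit leaves the size open). For compound 3 the estimated half-maximal cytotoxic concentration is 100000 nM, with an expected range of 35000 nM to 200000 nM.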

Compound 3, half-maximal cytotoxic concentration: > 100000 nM
Compound 3: no number, only a limit; the forecaster's own chance of this, stated with the estimate: 65%; the middle value lies on the limit itself.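

In this assay compound 3 gives > 100000 nM, which is a limit and not a number. For the compounds shown here, no step among compound 1, compound 2 and compound 3 can therefore be read. The compounds shown leave open how their toxicity in this test compares: the limit of > 100000 nM in this assay, at which 3 of the 3 values shown sit.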